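Inverting Three Ring Stereocentres of a Somatostatin Ligand

The compounds below may be only part of what the source reports. "The series", "measured", "known", "first", "only" and "open" are said of these compounds alone.

Measured so far:
compound 1 `COC(=O)c1cc(CC(C)CN2CC3CCCCC3C(C(=O)N3CCN(c4ccc([N+](=O)[O-])cc4)CC3)C2)cc(C(=O)OC)c1`: 2.88 nM
compound 2 `COC(=O)c1cc(CC(C)CN2C[C@H]3CCCC[C@H]3[C@@H](C(=O)N3CCN(c4ccc([N+](=O)[O-])cc4)CC3)C2)cc(C(=O)OC)c1`: 107 nM
compound 3 `COC(=O)c1cc(CC(C)CN2C[C@@H]3CCCC[C@@H]3[C@H](C(=O)N3CCN(c4ccc([N+](=O)[O-])cc4)CC3)C2)cc(C(=O)OC)c1`: not yet measured

For the measured compounds named here, in an assay on isolated protein for binding affinity to somatostatin receptor type 3 (Homo sapiens) (a higher number here means weaker binding, a lower number tighter binding), compound 2 gives 107 nM and stands at the highest number of the two measured, with compound 1 as its only neighbour; the step of a 37-fold higher number from compound 1 to compound 2 (1.57 log units; beyond the scatter) is large and far beyond the scatter. This difference is bound up with the fact that one of compounds 1 and 2 is drawn with a defined configuration and the other without, at the place where they differ, so compound 2 is one defined stereoisomer drawn out of the undefined set that compound 1 represents. Compound 3 differs from compound 2 only in that (the two compounds have the same atoms and bonds; at least one stereo element is drawn with a configuration in one of them and without one in the other: 3 of 4 stereo elements differ; a stereocentre at a saturated ring carbon is drawn S in compound 2 and R in compound 3; a stereocentre at a saturated ring carbon is drawn R in compound 2 and S in compound 3; a stereocentre at a saturated ring carbon is drawn R in compound 2 and S in compound 3); nothing leaves or enters. Since compound 1 binds far more tightly than compound 2, the mirror-image arrangement in compound 3 is expected to carry that tighter binding, with an expected step of a 71-fold lower number from compound 2 to compound 3 (1.85 log units; beyond the scatter). Compound 3 is therefore estimated at 1.5 nM, in a range from 0.5 nM to 6 nM.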

Compound 3, dissociation constant: 1.35 nM
Beside the measured number, compound 3's estimate is 1.1-fold (0.05 log units) above it; the range from low to high includes it.
By their numbers in this assay, from the lowest: compound 3; then compound 1; then compound 2.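

In this assay, a 79-fold lower number from compound 2 to compound 3 (1.90 log units; beyond the scatter) comes with no atom gained or lost, so the full gap between two defined forms belongs to the three ring stereocentres, which compound 1, drawn without a configuration there, could not show. The a 2.1-fold lower number from compound 1 to compound 3 (0.33 log units; beyond the scatter) is modest but beyond the scatter, so compound 3 binds somewhat more tightly than compound 1 and compound 2 lies far from both. The tight binding therefore goes with the arrangement drawn in compound 3, and the difference is tied to the stereochemistry alone: the fact that one of compounds 2 and 3 is drawn with a defined configuration and the other without, at the place where they differ.

From the compounds shown here alone, the three ring centres change together here, so the share of each one stays open, as does the role of the fourth stereo element, which all three compounds leave undefined. Also open, going by these compounds, is whether this preference would hold with a carboxylic acid in place of the methyl esters.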